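Methoxy addition in an aryl-ether dihydropyrimidinone series

The compounds below may be only part of what the source reports. "The series", "measured", "known", "first", "only" and "open" are said of these compounds alone.

Compound 1 `C=C(C)[C@@H]1CC=C(Cn2cc(COc3cccc(C4NC(=O)NC(C)=C4C(=O)OCC)c3)nn2)CC1` and compound 2 `C=C(C)[C@@H]1CC=C(Cn2cc(COc3cc(C4NC(=O)NC(C)=C4C(=O)OCC)ccc3OC)nn2)CC1` share a core and differ by methoxy in place of hydrogen on an aromatic carbon. In a functional assay on PC-3 cells (Homo sapiens) for inhibition, read by sulforhodamine B assay, with a stated time of 48 h (a lower number here means a stronger inhibitor of growth, a higher number a weaker inhibitor of growth), compound 1 gives only a limit of the assay, > 100000 nM. In this assay compound 2 likewise gives only a limit, > 100000 nM. Going by the values given here, the step from compound 1 to compound 2 is therefore a step that the two limits leave unreadable from compound 1 to compound 2, and the sole evidence on it is the limit of > 100000 nM in this assay, at which 2 of the 3 values shown sit.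

Compound 3 `C=C(C)[C@@H]1CC=C(Cn2cc(COc3ccc(C4NC(=O)NC(C)=C4C(C)=O)cc3)nn2)CC1` carries a different core; the difference between the two cores is not broken down here. In this assay, among the compounds with values here, compound 3 gives 49300 nM, the only number in the set.

Compound 4 `C=C(C)[C@@H]1CC=C(Cn2cc(COc3ccc(C4NC(=O)NC(C)=C4C(C)=O)cc3OC)nn2)CC1` is not yet measured. It differs from compound 3 by methoxy in place of hydrogen on an aromatic carbon. This is the same kind of change as that from compound 1 to compound 2, not the same change: around the place of entry, the methoxy in compound 2 sits para to a large group, whereas in compound 4 it sits meta to a large group.

The step from compound 3 to compound 4 is expected to be a 1.1-fold higher number from compound 3 to compound 4 (0.05 log units; within the scatter). This expectation rests on the measured step from compound 1 to compound 2 being unreadable between two limits. It also rests on compound 3 giving 49300 nM as the only anchor. Compound 4 is estimated to give 55000 nM, within 20000 nM to 120000 nM, in this assay.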

Compound 4, concentration for total growth inhibition: 85700 nM
For compound 4 the middle estimate is 1.6-fold (0.19 log units) below the measured one, within the range that was stated.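

Going by these compounds alone, on the core of compound 3, methoxy in place of hydrogen on an aromatic carbon gives a 1.7-fold higher number from compound 3 to compound 4 (0.24 log units; within the scatter) in this assay, and this is the only readable instance of the change. Within the data shown here, on the core of compound 1, the step to compound 2 cannot be read, as both values are limits of the assay, and the sole evidence there is this: the limit of > 100000 nM in this assay, at which 2 of the 4 values shown sit. With one readable step and one unreadable step, no sizes can be compared, so carrying the change from one core to the other is neither supported nor contradicted, and compound 2 and compound 4 show the same kind of change rather than the same change.

From the compounds shown here alone, it remains open whether another group at the place of entry in compound 4, such as an amine, a carboxylic acid or a longer chain like ethoxy, would give a step beyond the scatter on the core of compound 3. The difference between the cores of compound 1 and compound 3 also remains unresolved, and reading it would take a pair of compounds that differ in one place only.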